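Phenyl replacing methoxycarbonyl on the shared core

The source may hold more compounds than are shown below. What is called first, only, known or untested is meant among the compounds shown, and "the series" means these compounds.

Compound 2 `COC(=O)/C=C1\C(=O)N(Cc2ccc(OC)cc2)c2ccc(-c3ccc(OC)cc3)cc21` carries a methoxycarbonyl on a double-bonded chain carbon bound to a double-bonded ring carbon. Among the measured compounds shown here, in a functional assay on K562 cells (Homo sapiens) for antiproliferative activity, read by MTT assay, with a stated time of 48 h (on this read-out lower numbers stand for stronger inhibition and higher numbers for weaker inhibition), compound 2 gives 1900 nM, the highest of the two numbers so far. For the measured compounds named here, its only neighbour is compound 1 `CCOC(=O)/C=C1\C(=O)N(Cc2ccc(OC)cc2)c2ccc(-c3ccc(OC)cc3)cc21`, which in this assay gives 1240 nM; the difference is a 1.5-fold higher number from compound 1 to compound 2 (0.19 log units; within the scatter), so the two compounds cannot be told apart here. Compound 3 `COc1ccc(CN2C(=O)/C(=C\c3ccccc3)c3cc(-c4ccc(OC)cc4)ccc32)cc1` differs from compound 2 by phenyl in place of methoxycarbonyl on a double-bonded chain carbon bound to a double-bonded ring carbon. Going by the values given here, the single measured step concerns only hydrogen in place of methyl on a saturated chain carbon bound to an oxygen next to a carbonyl group and says nothing about exchanging methoxycarbonyl for phenyl; no measured pair bears on this change. The step is therefore expected to be no larger than the scatter, estimated at a 1.3-fold lower number from compound 2 to compound 3 (0.10 log units; within the scatter), with a wide range. For compound 3 the estimate in this assay is 1500 nM, within 400 nM to 6000 nM.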

Compound 3, half-maximal inhibitory concentration: > 10000 nM
Compound 3 ended at the assay's limit; the forecaster's own chance of this, stated with the estimate: 10%; middle value at least 6.6-fold (0.82 log units) away from the limit.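

On the double-bonded chain carbon bound to a double-bonded ring carbon, this assay now shows a step beyond the scatter: phenyl in place of methoxycarbonyl gives an at least 5.2-fold higher number from compound 2 to compound 3 (0.72 log units; beyond the scatter), and phenyl in place of ethoxycarbonyl gives an at least 8.0-fold higher number from compound 1 to compound 3 (0.90 log units; beyond the scatter). Compound 3 gives only a limit of the assay, > 10000 nM, not a number, so both steps are lower bounds: the limit of > 10000 nM in this assay, at which 1 of the 3 values shown sits. This place is therefore not indifferent to its group: changing methyl to ethyl within the ester stayed within the scatter, while replacing the whole ester with phenyl did not.

These compounds do not separate the loss of the ester from the entry of the phenyl ring. From the compounds shown here alone, how a carboxylic acid, an amide or a longer-chain ester would read at this place remains open.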